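From glycine to valine amide: expected lipophilicity of compound 3

The source may report more compounds than this note shows. Statements on the series, on what has been measured and on what is new or still open speak of the compounds shown alone.

Among the compounds with values here, compound 2 `COc1cc(NC(C)CCCN2C(=O)CN(C(=O)CN)C2(C)C)c2ncccc2c1` stands lowest of the two numbers measured so far: in a physicochemical assay for lipophilicity, measured as octanol-water partition (a higher number here means a more lipophilic compound, a lower number a more polar compound), compound 2 gives 2.19. Compound 3 `COc1cc(NC(C)CCCN2C(=O)CN(C(=O)[C@H](N)C(C)C)C2(C)C)c2ncccc2c1` differs from it by isopropyl in place of hydrogen on a saturated chain carbon bound to an amine nitrogen and a carbonyl carbon. Within the data shown here, one measured step bears on this change. Compound 1 `COc1cc(NC(C)CCCN2C(=O)CN(C(=O)[C@H](N)CC(C)C)C2(C)C)c2ncccc2c1` gives 3.36 in this assay, and a number 1.17 log units lower from compound 1 to compound 2 (beyond the scatter). Isopropyl is one carbon shorter than isobutyl, so a rise somewhat smaller than that step is expected going the other way. Compound 3 is therefore estimated at 3.05, within 2.7 to 3.4, an expected step of a number 0.86 log units higher from compound 2 to compound 3 (beyond the scatter).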

Compound 3, partition coefficient: 2.93
The estimate for compound 3 lay 0.12 log units above the measured number; the measured number falls inside the stated range.
By their numbers in this assay, from the lowest: compound 2; then compound 3; then compound 1.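

In this assay, the side chain at this saturated chain carbon clearly matters even when it is only a small branched group (a number 0.74 log units higher from compound 2 to compound 3 (beyond the scatter)). Isopropyl does not match isobutyl, however (a number 0.43 log units lower from compound 1 to compound 3 (beyond the scatter)), so the three compounds rank by side group as hydrogen, then isopropyl, then isobutyl. Nothing available here explains these steps.

Three compounds cannot show whether this order extends to a longer chain such as n-hexyl. A benzyl group or a carboxylic acid at the same carbon also remains an open case.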